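Amide-linked amino acid extensions on a chromane acid series

The source may hold more compounds than are shown below. What is called first, only, known or untested is meant among the compounds shown, and "the series" means these compounds.

Measured compounds:
compound 1 `COc1cc2c(cc1O)CCC(C)(CC(=O)O)O2` — 92.5%
compound 2 `COc1cc2c(cc1O)CCC(C)(CC(=O)N[C@@H](C)C(=O)O)O2` — 100%

In an ADME assay on SH-SY5Y cells (Homo sapiens) for cytotoxicity, read by MTT assay, with a stated time of 24 h, tested at 25 uM (a higher number here means a weaker effect of the compound at the concentration tested, a lower number a stronger effect), compound 1 gives 92.5% and compound 2 gives 100%. Among the two numbers known, compound 2 has the higher one, but the step of a number 7.5 percentage points higher from compound 1 to compound 2 (within the scatter) is within the scatter, so no difference between the two is established; both leave the cells largely unaffected at the concentration used.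

Compound 3 `COc1cc2c(cc1O)CCC(C)(CC(=O)N[C@H](C(=O)O)C(C)C)O2` is not yet measured. Its difference from compound 2 is isopropyl in place of methyl on a saturated chain carbon bound to an amide-type nitrogen and a carbonyl carbon.

Going by the values given here, only one measured step exists, a number 7.5 percentage points higher from compound 1 to compound 2 (within the scatter), and it concerns a different place: the amide-linked acid entering in place of a hydroxy group on a carbonyl carbon. Among the compounds with values here, no step touches the saturated chain carbon where methyl gives way to isopropyl. That one step was within the scatter, and the starting point for compound 2 already sits at the upper end of the read-out, so for compound 3 no step beyond the scatter is expected in this assay. The step from compound 2 to compound 3 is estimated as a number 3 percentage points lower from compound 2 to compound 3 (within the scatter). Compound 3 is expected to give 97%, within 85% to 108%.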

Compound 3, a percentage reported as activity, at one concentration (the size of the read-out at that concentration, not a potency): 76.1%
Compound 3: the middle estimate sits 20.9 percentage points above what was measured, and the stated range ends above it.
By their numbers in this assay, from the lowest: compound 3; then compounds 1 and 2 (each within the scatter of the next).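

Going by these compounds alone, in (this assay) the saturated chain carbon bound to an amide-type nitrogen and a carbonyl carbon turns out to be a place where the read-out responds: isopropyl in place of methyl gives the first step that lies beyond the scatter (a number 23.9 percentage points lower from compound 2 to compound 3 (beyond the scatter)). The amide-linked extension is therefore not without effect in every form: (1-carboxy-2-methylpropyl)amino in place of hydroxy on a carbonyl carbon also moves the number beyond the scatter (a number 16.4 percentage points lower from compound 1 to compound 3 (beyond the scatter)), whereas (1-carboxyethyl)amino in that place does not (a number 7.5 percentage points higher from compound 1 to compound 2 (within the scatter)). Nothing at hand accounts for this step, so it stands as an observation on the read-out alone.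

Two side chains cannot show whether the number falls gradually as the group on that carbon grows or whether the fall is particular to isopropyl; ethyl, isobutyl or benzyl at the same carbon would separate these readings. From the compounds shown here alone, it also remains open whether the step depends on the terminal carboxylic acid, which a methyl ester or a primary amide in its place on the isopropyl-bearing chain would test.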